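This account rests on a few compounds, and the source may have more. Where it says the series, first, only, none or still open, it means among the compounds named here.

Working notes on the series. Compound 1 `CC(C)N(Cc1cccc(OCCCCCC(=O)O)c1)C(=O)c1ccc(-c2cccc3ccccc23)cc1` and compound 2 `CCOC(=O)CCCCCOc1cccc(CN(C(=O)c2ccc(-c3cccc4ccccc34)cc2)C(C)C)c1` share one core and differ only by ethyl in place of hydrogen on an oxygen next to a carbonyl group. In an ADME assay on BJ cells (Homo sapiens) for cytotoxicity, read by CellTiter-Glo and resazurin assay, with a stated time of 72 h (a higher number here means that more compound is needed for the effect, a lower number that less compound is needed), compound 1 reaches only a limit, < 1.3 nM. In this assay compound 2 likewise sits at a limit, > 26000 nM. Going by these compounds, the step of an at least 20000-fold higher number from compound 1 to compound 2 (4.30 log units; beyond the scatter) is thus bounded on both sides by limits, the limit of < 1.3 nM in this assay, at which 1 of the 2 values shown sits, and (the limit of > 26000 nM in this assay, at which 1 of the 2 values shown sits), so its true size is unknown beyond being large. Compound 2 therefore stands at the inactive end of the numbers shown, with a bound rather than a value. Compound 3 `CCOC(=O)CCCCCOc1cccc(CN(C(=O)c2ccc(-c3cnc(OC)nc3OC)cc2)C(C)C)c1` is the next step: 2,4-dimethoxypyrimidin-5-yl in place of naphthalen-1-yl on an aromatic carbon. For the measured compounds named here, the ester that accompanied the loss of activity between compound 1 and compound 2 is kept in compound 3, and no measured step bears on replacing the naphthalen-1-yl group. Going by the values given here, the only guide is the limit of compound 2, so no movement beyond the scatter is expected, and compound 3 is estimated in this assay at 26000 nM, range 6000 nM to 100000 nM, an expected step of a number no higher from compound 2 to compound 3 (the limit leaves the size open) that most likely again ends as a limit.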

Compound 3, half-maximal effective concentration: > 26000 nM
Compound 3: a limit, no number; the forecaster's own chance of this, stated with the estimate: 80%; the middle value lies on the limit itself.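

Compound 2 and compound 3 both stand at a limit in this assay, so no step can be read between them: the limit of > 26000 nM in this assay, at which 2 of the 3 values shown sit. The compounds shown leave open how far 2,4-dimethoxypyrimidin-5-yl in place of naphthalen-1-yl moves this read-out, with or without the ethyl.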